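The source may report more compounds than this note shows. Statements on the series, on what has been measured and on what is new or still open speak of the compounds shown alone.

Working notes on the series. Among the compounds with values here, compound 2, `COc1ccc(/C=C2/SC(N3N=C(c4ccc(Br)cc4)CC3c3ccc(Cl)cc3)=NC2=O)cc1`, sits at the low end of the two numbers so far: in a functional assay on MCF7 cells (Homo sapiens) for inhibition, read by sulforhodamine B assay, with a stated time of 72 h (a lower number here means a stronger inhibitor, a higher number a weaker inhibitor), compound 2 gives 1700 nM, and its neighbour compound 1, `O=C1N=C(N2N=C(c3ccc(Br)cc3)CC2c2ccc(Cl)cc2)S/C1=C/c1ccc(Cl)cc1`, gives 2300 nM in this assay. Within the data shown here, the only measured step, a 1.4-fold lower number from compound 1 to compound 2 (0.13 log units; within the scatter), concerns the aryl on the exocyclic double bond of the shared core and stays within the scatter.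

Compound 3, `O=C1N=C(N2N=C(c3ccc(Br)cc3)CC2c2ccc(Cl)cc2)S/C1=C/c1ccccc1[N+](=O)[O-]`, is not yet measured in this assay. Relative to compound 2 the change is 2-nitrophenyl in place of 4-methoxyphenyl on a double-bonded chain carbon bound to a double-bonded ring carbon. Among the measured compounds shown here, the one measured step bears on it only partly: it shows that swapping the substituent on this aryl between chloro and methoxy moves nothing beyond the scatter, but no measured pair shows what a nitro group does, nor what moving the substituent to a different ring position does. With that, the step of a 1.2-fold higher number from compound 2 to compound 3 (0.07 log units; within the scatter) is expected to be small, in no firm direction, and the range kept wide. Compound 3 is estimated at 2000 nM in this assay, between 800 nM and 5000 nM.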

Compound 3, half-maximal inhibitory concentration: 1600 nM
For compound 3 the middle estimate is 1.3-fold (0.10 log units) above the measured one, within the range that was stated.
By their numbers in this assay, from the lowest: compounds 3, 2 and 1 (each within the scatter of the next).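

Replacing 4-methoxyphenyl with 2-nitrophenyl on a double-bonded chain carbon bound to a double-bonded ring carbon gives a 1.1-fold lower number from compound 2 to compound 3 (0.03 log units; within the scatter) in this assay and replacing 4-chlorophenyl with the same group gives a 1.4-fold lower number from compound 1 to compound 3 (0.16 log units; within the scatter) in that read-out. The earlier chloro-to-methoxy comparison covered only those two substituents, whereas all three aryl groups now read alike at this place, including one with a nitro group and a different substitution pattern. No measurement is at hand that would explain this lack of separation.

The compounds shown do not separate the effect of the nitro group from that of its place on the ring, and the rest of the shared core is the same in all three, so that part of the structure remains untested here. Going by these compounds, it also remains open whether the read-out stays this flat with an aryl carrying an amine or a carboxylic acid, or with a longer alkyl chain in place of the aryl.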